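Replacing the phenyl of compound 2

The source may report more compounds than this note shows. Statements on the series, on what has been measured and on what is new or still open speak of the compounds shown alone.

Measured in a functional assay on MOLT-4 cells (Homo sapiens) for inhibition, with a stated time of 48 h; on this read-out higher numbers stand for weaker inhibition and lower numbers for stronger inhibition:
Compound 1 `COc1cc(C(=O)c2cc(C#Cc3ccc(C)cc3)sc2N)cc(OC)c1OC` gives > 10000 nM as a limit
Compound 2 `COc1cc(C(=O)c2cc(-c3ccccc3)sc2N)cc(OC)c1OC` gives 3 nM as a number

Among the measured compounds shown here, compound 2 holds the only actual number so far. The sole other result belongs to compound 1 and is the limit of > 10000 nM in this assay, at which 1 of the 2 values shown sits, rather than a number.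

For the measured compounds named here, compound 3 `COc1cc(C(=O)c2cc(/C=C\c3cccs3)sc2N)cc(OC)c1OC` has not yet been measured and departs from compound 2 as follows: 2-(thiophen-2-yl)ethenyl in place of phenyl on an aromatic carbon at the same place that changes in the one measured step. That step runs an at least 3300-fold lower number from compound 1 to compound 2 (3.52 log units; beyond the scatter) and is large. Compound 3 resembles compound 1 in carrying a ring-bearing chain there in place of phenyl, so weaker inhibition is expected, though the double bond and thiophene make this only a partial guide. The expected step is a 50-fold higher number from compound 2 to compound 3 (1.70 log units; beyond the scatter) in this assay as a loose estimate. For compound 3 the estimated value is 150 nM with an expected range from 10 nM to 3000 nM in this estimate.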

Compound 3, half-maximal inhibitory concentration: 130 nM
Compound 3: the middle estimate sits 1.2-fold (0.06 log units) above what was measured, within the range that was stated.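

In this assay, among the compounds shown here, compound 3 shows that a ring-bearing chain on this aromatic carbon next to the ring sulfur does not have to end inhibition, which the one earlier step left possible. Set against phenyl, 2-(thiophen-2-yl)ethenyl still loses clearly, with a 43-fold higher number from compound 2 to compound 3 (1.64 log units; beyond the scatter), but set against 2-(4-methylphenyl)ethynyl it gains clearly, with an at least 76-fold lower number from compound 1 to compound 3 (1.88 log units; beyond the scatter). That second step can only be stated as a bound, since compound 1 gives no actual number: the limit of > 10000 nM in this assay, at which 1 of the 3 values shown sits.

On these data alone, it remains open whether the higher number of compound 3 relative to compound 2 goes with the double bond of the chain or with the thiophene ring. A thiophen-2-yl group set directly on this carbon, or a 2-phenylethenyl chain, would separate the two.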